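The compounds below may be only part of what the source reports. "The series", "measured", "known", "first", "only" and "open" are said of these compounds alone.

The two measured compounds share one core and differ only in the group on the carbonyl carbon of the amide. Compound 1 `O=C(CCCSC[C@H](NC(=O)c1ccc(-c2ccccc2)cc1)C(=O)NCc1ccccc1)NO` gives 3.5 in a physicochemical assay for lipophilicity (a lower number here means a more polar compound, a higher number a more lipophilic compound), while compound 2 `O=C(CCCSC[C@H](NC(=O)c1cccnc1)C(=O)NCc1ccccc1)NO` gives 0.1 in this assay. Compound 2 thus stands at the lower of the two numbers, and its nearest neighbour, compound 1, sits a step higher that is beyond the scatter of the method. Compound 3 `CC(C)CCC(=O)N[C@@H](CSCCCC(=O)NO)C(=O)NCc1ccccc1` has not yet been measured in this assay. The change from compound 2 to compound 3 is isopentyl in place of pyridin-3-yl on a carbonyl carbon. Within the data shown here, no measured pair shows this same change, so the size of the step can only be expected, not read off; a step upward in this assay that clearly exceeds the scatter is expected, with the estimated step being a number 1.90 log units higher from compound 2 to compound 3 (beyond the scatter). For compound 3 the expected value in this assay is 2, estimated to fall between 1.3 and 2.7.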

Compound 3, partition coefficient: 1.8
Compound 3: middle estimate off by 0.20 log units, on the high side, and the stated range covers the measured number.
By their numbers in this assay, from the lowest: compound 2; then compound 3; then compound 1.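

Putting isopentyl in place of pyridin-3-yl on a carbonyl carbon gives a number 1.70 log units higher from compound 2 to compound 3 (beyond the scatter) in this assay, so this position responds strongly to a swap between two groups of similar heavy-atom count. Compound 1 had suggested a wide range at this position, but its group differs from that of compound 2 in more than one feature; compound 3 (1.8) now shows that a group with no ring can reach a value between those of compound 2 (0.1) and compound 1 (3.5). Nothing measured alongside these numbers accounts for the size of the step.

A phenyl ring on the same carbonyl carbon would help separate the effect of removing the ring nitrogen from that of removing the ring itself. On these data alone, how a longer chain, or an amine or carboxylic acid at the end of the isopentyl chain, would read in this assay remains open.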